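Moving the Ring Nitrogen of the Pyridyl Group

The compounds below may be only part of what the source reports. "The series", "measured", "known", "first", "only" and "open" are said of these compounds alone.

In an assay on LM cells for displacement of a labelled ligand from Neuropeptide Y receptor type 5 (Homo sapiens) (on this read-out lower numbers stand for stronger inhibition and higher numbers for weaker inhibition), compound 1 `CC(=O)c1cccc(C2=NC(c3ccc(F)cc3)(c3ccc(F)cc3)CN2)c1` gives 44 nM. In this assay compound 2 `Fc1ccc(C2(c3ccc(F)cc3)CNC(c3ccccn3)=N2)cc1` gives 160 nM, the higher of the two numbers recorded. Among the compounds with values here, the only measured step, a 3.6-fold higher number from compound 1 to compound 2 (0.56 log units; beyond the scatter), concerns a different group at the same carbon. Compound 3 `Fc1ccc(C2(c3ccc(F)cc3)CNC(c3ccncc3)=N2)cc1` matches compound 2 except that (pyridin-4-yl in place of pyridin-2-yl on a carbon with a double bond to nitrogen). Within the data shown here, no measured step covers this change, so the expectation rests on compound 2 alone and on the absence of any guide. Compound 3 is therefore expected at 220 nM, within 60 nM to 800 nM, an expected step of a 1.4-fold higher number from compound 2 to compound 3 (0.14 log units; within the scatter) that need not exceed the scatter.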

Compound 3, half-maximal inhibitory concentration: 160 nM
Compound 3: the middle estimate sits 1.4-fold (0.14 log units) above what was measured, within the range that was stated.
By their numbers in this assay, from the lowest: compound 1; then compounds 2 and 3 (each within the scatter of the next).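

Swapping pyridin-2-yl for pyridin-4-yl gives no change at the digits printed from compound 2 to compound 3 (within the scatter) in this assay, so on this carbon the two placements of the ring nitrogen cannot be told apart. The replacement of 3-acetylphenyl by pyridin-4-yl costs as much as the one by pyridin-2-yl, with a 3.6-fold higher number from compound 1 to compound 3 (0.56 log units; beyond the scatter), leaving 3-acetylphenyl the better group at this carbon. No available evidence explains this insensitivity. On these data alone, whether pyridin-3-yl would read the same remains open. So does whether an amine or a carboxylic acid on the pyridine ring would shift the number.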